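Hydroxy to methoxy on compound 2

The compounds below may be only part of what the source reports. "The series", "measured", "known", "first", "only" and "open" are said of these compounds alone.

Of the compounds shown here, two have numbers so far. In a functional assay on A-431 cells (Homo sapiens) for antiproliferative activity (a lower number here means a stronger inhibitor, a higher number a weaker inhibitor), compound 1 `CCOC(=O)CNC(=O)O[C@@H]1CO[C@]2(COC(C)(C)O2)[C@@](O)(C2OC2CC(C)C)[C@@H]1OC` gives 442000 nM as its half-maximal inhibitory concentration. Compound 2 `CO[C@@H]1[C@H](OC(=O)NC(=O)CCl)CO[C@]2(COC(C)(C)O2)[C@@]1(O)C1(C)CO1` gives 84000 nM in this assay and holds the lower of the two numbers, which makes it the stronger inhibitor of the pair, with a gap beyond the scatter of repeated measurements.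

Compound 3 `CO[C@@H]1[C@H](OC(=O)NC(=O)CCl)CO[C@]2(COC(C)(C)O2)[C@@]1(OC)C1(C)CO1` differs from compound 2 in one place: methyl in place of hydrogen on an oxygen on a saturated carbon, read one bond further out as hydroxy to methoxy, counted as methyl in place of hydrogen on an oxygen on a saturated carbon with the rest of the structure unchanged. Among the compounds with values here, no measured pair shows this change, so no direct precedent exists. The expectation starts from compound 2 at 84000 nM as the closest measured structure. The expected step of a 1.1-fold lower number from compound 2 to compound 3 (0.02 log units; within the scatter) is small and stays within the scatter, with no direction assigned. In this assay the estimated value for compound 3 is 80000 nM with an expected range from 25000 nM to 250000 nM around it.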

Compound 3, half-maximal inhibitory concentration: 39000 nM
Compound 3: the middle estimate sits 2.1-fold (0.31 log units) above what was measured, within the range that was stated.
By their numbers in this assay, from the lowest: compound 3; then compound 2; then compound 1.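

In this assay, within the data shown here, methyl in place of hydrogen on an oxygen on a saturated carbon, read as hydroxy to methoxy, gives a 2.2-fold lower number from compound 2 to compound 3 (0.33 log units; beyond the scatter), a modest step beyond the scatter and the first single-place comparison. At this position the free hydroxy is therefore not needed for the activity of this pair, and its replacement by methoxy gives the lower number, with compound 3 at 39000 nM. Nothing available explains the size or direction of this step.

This single pair leaves open whether the trend depends on methyl specifically or would continue with an ethyl ether, a benzyl ether or an acetate ester on the same oxygen. Among these compounds, compound 1 differs from compound 2 in more than one place, so no step connects it to the other compounds, and the separate contributions of its differences cannot be read.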